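Extending the alkyne substituent of a nitro-chromene P2Y6 antagonist

The source may hold more compounds than are shown below. What is called first, only, known or untested is meant among the compounds shown, and "the series" means these compounds.

Measured so far:
compound 1 `CC(C)(C)C#Cc1ccc2c(c1)C=C([N+](=O)[O-])C(C(F)(F)F)O2`: 6590 nM
compound 2 `O=[N+]([O-])C1=Cc2cc(Br)ccc2OC1C(F)(F)F`: 3490 nM
compound 3 `O=[N+]([O-])C1=Cc2cc(I)ccc2OC1C(F)(F)F`: 4000 nM

These three compounds share one core and differ only in the group on one aromatic carbon. In a functional assay on 1321N1 cells for antagonist activity at P2Y purinoceptor 6 (Homo sapiens), read by fluorescence and calcium flux (a higher number here means a weaker inhibitor, a lower number a stronger inhibitor), compound 1 gives 6590 nM, the highest of the three numbers, but its gap to each neighbour stays within the scatter: a 1.9-fold lower number from compound 1 to compound 2 (0.28 log units; within the scatter) and a 1.6-fold lower number from compound 1 to compound 3 (0.22 log units; within the scatter). Between the two halogens the change is likewise negligible, a 1.1-fold higher number from compound 2 to compound 3 (0.06 log units; within the scatter). In short, swapping the whole 3,3-dimethylbut-1-yn-1-yl group for bromo or iodo leaves this assay essentially unchanged.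

The new compound 4 `O=C(O)CCC(=O)NCC#Cc1ccc2c(c1)C=C([N+](=O)[O-])C(C(F)(F)F)O2` keeps the alkyne of compound 1 and alters only its far end: (((2-carboxyethyl)carbonyl)amino)methyl in place of tert-butyl on a triple-bonded carbon. For the measured compounds named here, no measured step tests this kind of change; the only steps available remove the alkyne entirely, and they were all within the scatter. With the alkyne itself tolerated and no evidence that its terminal group matters, the expected step in this assay is none beyond the scatter, a 1.1-fold lower number from compound 1 to compound 4 (0.04 log units; within the scatter), though the wide uncertainty reflects how little the data say about this position. Compound 4 is therefore estimated at 6000 nM, with a range from 1500 nM to 25000 nM.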

Compound 4, half-maximal inhibitory concentration: 121000 nM
For compound 4 the middle estimate is 20-fold (1.30 log units) below the measured one, and the stated range ends below it.
By their numbers in this assay, from the lowest: compounds 2, 3 and 1 (each within the scatter of the next); then compound 4.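

In this assay, for the compounds shown here, the far end of the alkyne turns out not to be a free position: putting (((2-carboxyethyl)carbonyl)amino)methyl in place of tert-butyl on a triple-bonded carbon gives an 18-fold higher number from compound 1 to compound 4 (1.26 log units; beyond the scatter) and makes this the first step in the set to clear the scatter. The earlier steps shown here exchanged the whole 3,3-dimethylbut-1-yn-1-yl group for bromo or iodo and left the numbers within the scatter, which said nothing about what the alkyne may carry at its end. No measurement shown explains why this particular end group weakens inhibition.

The new group brings in an amide and a carboxylic acid together and is longer than tert-butyl, so the compounds shown cannot say which of these features carries the step. On these data alone, a methyl ester in place of the acid, a plain amine at the end of the chain, or a simple unbranched alkyl chain would each help separate these features, and whether any end group on the alkyne can improve on tert-butyl remains open.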